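Removing a Methoxy Group from a Partial Agonist

This account rests on a few compounds, and the source may have more. Where it says the series, first, only, none or still open, it means among the compounds named here.

Of the compounds shown here, two have so far been measured in an assay on CHO cells with Alpha-2B adrenergic receptor (Homo sapiens) as the target; a higher number here means a larger maximal response, a lower number a smaller maximal response. Compound 1 `COC1(C2=NCCN2)COc2c(cccc2-c2ccccc2)O1` gives 0.5 in this assay, while compound 2 `CC(Oc1ccccc1/C=N/O)C1=NCCN1` gives 0.5 in this assay. At the digits shown these two numbers are level, and the gap between them lies within the usual scatter of repeated measurements, so compound 1 stands neither above nor below compound 2 on intrinsic activity.

Compound 3 `c1ccc(-c2cccc3c2OCC(C2=NCCN2)O3)cc1` has not yet been measured in this assay. It differs from compound 1 by hydrogen in place of methoxy on a saturated ring carbon. Within the data shown here, no pair of measured compounds shows the effect of this particular change, so its direction cannot be read from the data. What the data do show is that two rather different compounds, compound 1 and compound 2, reach the same fraction of the reference response. On that basis the step from compound 1 to compound 3 is expected to be small, no change at the digits printed from compound 1 to compound 3 (within the scatter), or none beyond the scatter. Compound 3 is therefore estimated to give 0.5 in this assay, with a likely range from 0.3 to 0.7.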

Compound 3, intrinsic activity: the largest response reached, as a fraction of the reference agonist's: 0.7
Beside the measured number, compound 3's estimate is 0.20 below it; measured number inside the range.
By their numbers in this assay, from the lowest: compounds 1 and 2 (each within the scatter of the next); then compound 3.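

In this assay, among these compounds, putting hydrogen in place of methoxy on this saturated ring carbon gives a number 0.20 higher from compound 1 to compound 3 (beyond the scatter), the only step here between measured compounds that differ in one place. This shows that the position is not silent: what sits on this carbon can change the maximal response, and of the two groups compared, hydrogen goes with the larger response. No evidence is available on what lies behind this rise.

Methoxy and hydrogen are the only groups shown on this carbon, so it remains open whether a hydroxyl, a methyl or a longer chain such as ethoxy would give a response closer to that of compound 1 or compound 3, or one outside both. Going by these compounds, because the step rests on a single pair of compounds, it also remains open whether removing methoxy would have a similar effect on the response if the rest of the molecule were changed, for example if the phenyl group of compound 3 were replaced by a methyl group.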